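The source may hold more compounds than are shown below. What is called first, only, known or untested is meant among the compounds shown, and "the series" means these compounds.

Measured so far in an assay on isolated protein for inhibition of phosphodiesterase 4A (Sus scrofa); on this read-out higher numbers stand for weaker inhibition and lower numbers for stronger inhibition:
compound 1, `COc1ccc(C(=O)Nc2c(F)cccc2F)cc1OC1CCCC1`, gives 70 nM
compound 2, `COc1ccc(C(=O)Nc2c(F)cccc2Cl)cc1OC1CCCC1`, gives 240 nM
compound 3, `COc1ccc(C(=O)Nc2c(F)c(F)nc(F)c2F)cc1OC1CCCC1`, gives 550 nM

Compounds 1 and 2 share a core and differ in one place: chloro in place of fluoro on an aromatic carbon. That change gave a 3.4-fold higher number from compound 1 to compound 2 (0.54 log units; beyond the scatter). Compound 3 carries a different core, and the difference between the two cores is not broken down here; in this assay compound 3 stands highest of the three numbers.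

Compound 4, `COc1ccc(C(=O)Nc2c(F)c(F)nc(F)c2Cl)cc1OC1CCCC1`, has not yet been measured. It differs from compound 3 by chloro in place of fluoro on an aromatic carbon. This is the same kind of change as that from compound 1 to compound 2, but here it sits on a six-membered aromatic ring with 1 nitrogen, two atoms from the ring nitrogen and ortho, meta and para to a fluoro group, whereas in compound 2 the ring is of carbon only.

Compound 4 is expected, resting on the step seen in a 3.4-fold higher number from compound 1 to compound 2 (0.54 log units; beyond the scatter), to show a 2.7-fold higher number from compound 3 to compound 4 (0.44 log units; beyond the scatter), and so an estimated 1500 nM in this assay, with a range from 500 nM to 5000 nM.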

Compound 4, half-maximal inhibitory concentration: 100 nM
Compound 4: the middle estimate sits 15-fold (1.18 log units) above what was measured; the measured number lies below the stated range.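

In this assay, chloro in place of fluoro on an aromatic carbon gave a 5.5-fold lower number from compound 3 to compound 4 (0.74 log units; beyond the scatter). The same change therefore did not carry over from the core of compound 1 to the core of compound 3, and its direction reversed: the same change on two cores in this assay, a 3.4-fold higher number (0.54 log units; beyond the scatter) from compound 1 to compound 2 and a 5.5-fold lower number (0.74 log units; beyond the scatter) from compound 3 to compound 4, 19-fold (1.28 log units) apart, beyond the scatter of two such steps. With one pair on each core, this shows that the step from one core cannot be assumed on the other, but it does not show why the two differ or how the change would behave on a further core.

The compounds shown leave open whether bromo, methyl or methoxy at this place would follow the chloro step on either core. They also leave open whether the reversal goes with the ring nitrogen or with the further fluoro groups on the core of compound 3.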